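Adding a Methyl Group to a Pyridine Amide

The source may hold more compounds than are shown below. What is called first, only, known or untested is meant among the compounds shown, and "the series" means these compounds.

Of the compounds shown here, three sharing one core have been measured in an assay on isolated protein for binding affinity to metabotropic glutamate receptor 5 (Homo sapiens); on this read-out higher numbers stand for weaker inhibition and lower numbers for stronger inhibition. Compound 1 `O=C(Nc1cccc(Cl)c1)c1cccc2oc(=O)[nH]c12` gives 68 nM, compound 2 `O=C(Nc1ccccc1)c1cccc2oc(=O)[nH]c12` gives 2200 nM, and compound 3 `O=C(Nc1ccccn1)c1cccc2oc(=O)[nH]c12` gives 251 nM. Compound 3 thus stands second highest of the three numbers: its value lies between those of compound 1 and compound 2, and the step of an 8.8-fold lower number from compound 2 to compound 3 (0.94 log units; beyond the scatter) was modest.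

Compound 4 `Cc1cccc(NC(=O)c2cccc3oc(=O)[nH]c23)n1` differs from compound 3 by methyl in place of hydrogen on an aromatic carbon. For the measured compounds named here, the only measured step that changed a substituent on the amide aryl ring, a 32-fold higher number from compound 1 to compound 2 (1.51 log units; beyond the scatter), was large, so a group on that ring can shift the number strongly. A methyl is not a chloro, however, and the ring here carries a nitrogen, so a smaller shift, toward stronger binding, is expected. Compound 4 is therefore expected to give 100 nM, within a range of 30 nM to 400 nM. That estimate means an expected step of a 2.5-fold lower number from compound 3 to compound 4 (0.40 log units; beyond the scatter).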

Compound 4, inhibition constant: 95 nM
For compound 4 the middle estimate is 1.1-fold (0.02 log units) above the measured one; the measured number falls inside the stated range.
By their numbers in this assay, from the lowest: compounds 1 and 4 (each within the scatter of the next); then compound 3; then compound 2.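

A single methyl on an aromatic carbon, next to the ring nitrogen and meta to a large group, gives a 2.6-fold lower number from compound 3 to compound 4 (0.42 log units; beyond the scatter), a step beyond the scatter. The earlier compounds shown here showed a substituent changing the number only on a phenyl ring, whereas this result shows that the six-membered ring with one nitrogen can also carry one, with stronger inhibition. Nothing measured here accounts for this step. As far as these compounds go, it remains open whether an ethyl group, a longer chain or an amine in this same place would lower the number further or raise it. From the compounds shown here alone, the effect of a methyl elsewhere on this ring also remains open.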